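A few compounds are considered here, and "the series" means these few. Any claim that something is new, unique, unknown or untested is made for them only; others in the source may bear on it.

Working notes on the series. Compound 1 `CC(C(=O)N1CCN(c2ccc(Cl)cc2)CC1)N1C(=O)CCC1=O` gives 25% in a functional assay on the whole organism (strain Swiss) with Mus musculus as the target, in the maximal electroshock model, with a stated time of 0.5 h, at a dose of 100 mg/kg by the intraperitoneal route; on this read-out lower numbers stand for a weaker effect and higher numbers for a stronger effect at the one dose given. Compound 2 `CC(C(=O)N1CCN(c2ccc(F)cc2)CC1)N1C(=O)CCC1=O` gives 0% in this assay, and compound 3 `CCC(C(=O)N1CCN(c2cccc(F)c2)CC1)N1C(=O)CCC1=O` gives 0%. Compound 2 thus stands level with compound 3 at the digits shown, the two together the lowest of the three numbers, with compound 1 the furthest from it and higher. Within the data shown here, the only measured single step, a number 25 percentage points lower from compound 1 to compound 2 (beyond the scatter), is the one that bears on the move to compound 4 `Cc1cccc(N2CCN(C(=O)C(C)N3C(=O)CCC3=O)CC2)c1`, which is 3-methylphenyl in place of 4-fluorophenyl on an amine nitrogen in a ring. That step also exchanged a group on the aromatic ring, so a step of similar modest size is expected here, upward from the floor. Compound 4 is expected to give 10%, within 0% to 35%. The estimated step is a number 10 percentage points higher from compound 2 to compound 4 (within the scatter).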

Compound 4, a percentage reported as activity, at one dose (the size of the read-out at that dose, not a potency): 0%
For compound 4 the middle estimate is 10 percentage points above the measured one, within the range that was stated.
By their numbers in this assay, from the lowest: compounds 2, 3 and 4 (each within the scatter of the next); then compound 1.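

At the amine nitrogen in a ring, 3-methylphenyl in place of 4-fluorophenyl gives no change at the digits printed from compound 2 to compound 4 (within the scatter) in this assay, so a methyl-bearing ring reads the same here as a fluorine-bearing one. Against the 4-chlorophenyl group, 3-methylphenyl gives a number 25 percentage points lower from compound 1 to compound 4 (beyond the scatter), which leaves that chlorine-bearing ring as the only one here with a reading off the floor. Nothing available explains this pattern. Still open, going by these compounds, is how a bromine or a methoxy group on the aromatic ring would read in this assay. The compounds shown also leave open whether a chlorine on the 3-position of the ring would hold the reading of compound 1.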